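The compounds below may be only part of what the source reports. "The series", "measured", "known", "first", "only" and "open" are said of these compounds alone.

Compound 1 `CC(Sc1nc(SC(C)C(N)=O)c2cnn(-c3ccccc3)c2n1)C(N)=O`: 229 nM
Compound 2 `CCNC(=O)CSc1nc(N)c2cnn(-c3ccccc3)c2n1`: 12.1 nM
Compound 3 `NC(=O)CCSc1nc(N)c2cnn(-c3ccccc3)c2n1`: 428 nM

Three compounds sharing one core were measured in an assay on cell membranes for binding affinity to adenosine receptor A1 (Rattus norvegicus); a lower number here means a stronger inhibitor, a higher number a weaker inhibitor. Compound 3 gives 428 nM, the highest of the three numbers; compound 1 gives 229 nM, which lies within the scatter of compound 3, while compound 2 gives 12.1 nM, far apart from it.

Compound 4 `CCNC(=O)CCSc1nc(N)c2cnn(-c3ccccc3)c2n1` is the next compound. Relative to compound 3 the change is ethyl in place of hydrogen on an amide-type nitrogen. Among the compounds with values here, only one measured step touches this change: a 35-fold higher number from compound 2 to compound 3 (1.55 log units; beyond the scatter), which is large, but it combines the loss of the ethyl group with a lengthening of the chain on the sulfur, so the share of the ethyl alone cannot be read from it. Putting the ethyl back onto compound 3 while the longer chain stays is therefore expected to recover only part of that step, giving a moderately lower number in this assay. For compound 4 the estimated step is a 3.1-fold lower number from compound 3 to compound 4 (0.49 log units; beyond the scatter). Compound 4 is thus expected to give about 140 nM, with a range from 40 nM to 500 nM.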

Compound 4, inhibition constant: 551 nM
For compound 4 the middle estimate is 3.9-fold (0.60 log units) below the measured one, and the stated range ends below it.
By their numbers in this assay, from the lowest: compound 2; then compounds 1, 3 and 4 (each within the scatter of the next, the first and the last beyond it).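

In this assay, ethyl on the amide-type nitrogen makes no clear difference on the chain of compound 3, with a 1.3-fold higher number from compound 3 to compound 4 (0.11 log units; within the scatter) staying within the scatter. With the ethyl present on both sides, the chain change alone gives a 46-fold higher number from compound 2 to compound 4 (1.66 log units; beyond the scatter) and is large, so the earlier large step can now be tied to the chain rather than to the ethyl. Nothing available explains why this chain change matters so much.

On these data alone, it remains open whether ethyl matters on the chain of compound 2, which would take the plain carbamoyl on that chain to show. Also open, as far as these compounds go, is how a propyl or benzyl on that nitrogen, or a carboxylic acid in place of the amide, would behave on either chain.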